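Ether swap on the limit compound of the series

A few compounds are considered here, and "the series" means these few. Any claim that something is new, unique, unknown or untested is made for them only; others in the source may bear on it.

Measured in an ADME assay on KB cells (Homo sapiens) for cytotoxicity; a lower number here means that less compound is needed, a higher number that more compound is needed for the effect:
- compound 1 `CCOc1c(OC)c(OC)cc2c1C(=O)[C@]1(OC)C=C[C@H]2N(C(=O)OCC(C)C)N1C(=O)OCC(C)C` gives > 300 ug/mL (a limit)
- compound 2 `CCOC(=O)N1[C@@H]2C=C[C@@](OC)(C(=O)c3c2cc(OC)c(OC)c3OCc2ccccc2F)N1C(=O)OCC` gives 99.7 ug/mL
- compound 3 `COC(=O)N1[C@@H]2C=C[C@@](OC)(C(=O)c3c2cc(OC)c(OC)c3OCc2ccc(Cl)cc2)N1C(=O)OC` gives 55.9 ug/mL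

Compound 1 stands at the limit of > 300 ug/mL in this assay, at which 1 of the 3 values shown sits, and so has a limit, not a number. The next compound to read is compound 4 `COc1ccc(COc2c(OC)c(OC)cc3c2C(=O)[C@]2(OC)C=C[C@H]3N(C(=O)OCC(C)C)N2C(=O)OCC(C)C)cc1`. Its change from compound 1 is 4-methoxyphenyl in place of methyl on a saturated chain carbon bound to an oxygen on an aromatic ring, in which ethoxy gives way to (4-methoxybenzyl)oxy. Compound 2 at 99.7 ug/mL and compound 3 at 55.9 ug/mL also carry an aromatic ring on that ether chain, although both differ from compound 1 elsewhere too. On that basis a clear move to a lower number is expected, an at least 5.0-fold lower number from compound 1 to compound 4 (0.69 log units; beyond the scatter). For compound 4 the estimated value is 60 ug/mL, with an expected range from 15 ug/mL to 250 ug/mL.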

Compound 4, concentration for half-maximal effect: 47.9 ug/mL
For compound 4 the middle estimate is 1.3-fold (0.10 log units) above the measured one; the range from low to high includes it.
By their numbers in this assay, from the lowest: compounds 4, 3 and 2 (each within the scatter of the next, the first and the last beyond it). At a limit, above all of these: compound 1.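

The swap of methyl for 4-methoxyphenyl on a saturated chain carbon bound to an oxygen on an aromatic ring gives the series its first single-place step in this assay: an at least 6.2-fold lower number from compound 1 to compound 4 (0.79 log units; beyond the scatter). Within the data shown here, this position therefore responds to the change, which no earlier pair could show. Compound 1 stands at a limit rather than a number, so the true size of the step stays unknown: the limit of > 300 ug/mL in this assay, at which 1 of the 4 values shown sits.

Going by these compounds, whether the step depends on the aromatic ring itself or on its methoxy group remains open. Also open, on these data alone, is how an amine or a carboxylic acid on that ether chain would read.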